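A Methyl Added to the Five-Membered Ring of Compound 3

The compounds below may be only part of what the source reports. "The series", "measured", "known", "first", "only" and "open" are said of these compounds alone.

Three related compounds have been tested in a functional assay on HeLa cells (Homo sapiens) for cytotoxicity, read by MTT assay, with a stated time of 72 h; a lower number here means a stronger inhibitor, a higher number a weaker inhibitor. Compound 1 `Cc1cc(-c2ccccc2)n(/C(N)=N/S(=O)(=O)c2cc(C)c(Cl)cc2SCc2ccc(C(F)(F)F)cc2)n1` gives 19000 nM. Going by the values given here, compound 2 `Cc1cc(-c2ccccc2)n(/C(N)=N/S(=O)(=O)c2cc(C)c(Cl)cc2SCc2cccc(Cl)c2)n1` gives 8000 nM, and the change between them, a 2.4-fold lower number from compound 1 to compound 2 (0.38 log units; beyond the scatter), is the only step recorded between two compounds that differ in one place. Compound 3 `Cc1ccc(CSc2cc(Cl)c(C)cc2S(=O)(=O)/N=C(\N)n2nccc2-c2ccccc2)cc1` gives 17000 nM; this number lies within the scatter of compound 1, while compound 2 sits beyond the scatter on the lower side.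

Compound 4 `Cc1ccc(CSc2cc(Cl)c(C)cc2S(=O)(=O)/N=C(\N)n2nc(C)cc2-c2ccccc2)cc1` has not yet been measured. It differs from compound 3 by methyl in place of hydrogen on an aromatic carbon. Among the compounds with values here, compounds 1 and 2 both carry this methyl on their five-membered ring, but neither is paired with a partner lacking it, so no measured step speaks directly to this change; the single step recorded concerns the group on the saturated chain carbon bound to a sulfur, not the five-membered ring. With no guidance from the data, the expectation is that the methyl brings no shift beyond the scatter in this assay. Compound 4 is therefore expected to give about 17000 nM, between 7000 nM and 40000 nM. This expectation amounts to no change at the digits printed from compound 3 to compound 4 (within the scatter), a step within the scatter.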

Compound 4, half-maximal inhibitory concentration: 62000 nM
Beside the measured number, compound 4's estimate is 3.6-fold (0.56 log units) below it; the whole stated range lies below it.
By their numbers in this assay, from the lowest: compound 2; then compounds 3 and 1 (each within the scatter of the next); then compound 4.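

In this assay the methyl on the aromatic carbon of the five-membered ring, two ring bonds from the ring atom that bears the phenyl group, can now be read directly, and it is not a neutral swap: the step is a 3.6-fold higher number from compound 3 to compound 4 (0.56 log units; beyond the scatter) toward a weaker compound. With that methyl held in place, the group on the saturated chain carbon bound to a sulfur also counts: the step with 4-methylphenyl in place of 3-chlorophenyl is a 7.8-fold higher number from compound 2 to compound 4 (0.89 log units; beyond the scatter) and the step with 4-methylphenyl in place of 4-(trifluoromethyl)phenyl is a 3.3-fold higher number from compound 1 to compound 4 (0.51 log units; beyond the scatter) and these leave compound 4 the weakest of the four. Nothing measured here explains why one added methyl has this effect.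

As far as these compounds go, whether the ring methyl moves the number the same way alongside 3-chlorophenyl or 4-(trifluoromethyl)phenyl stays open: compound 1 and compound 2 have no partner lacking it. Also open, from the compounds shown here alone, is what an ethyl group, an amine or a carboxylic acid on this ring carbon would do to the number.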